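A few compounds are considered here, and "the series" means these few. Any claim that something is new, unique, unknown or untested is made for them only; others in the source may bear on it.

Measured compounds:
compound 1 `CCN(C/C=C/C#CC(C)(C)C)Cc1cccc(OCCNS(=O)(=O)c2cccs2)c1` in a functional assay on HepG2 cells for inhibition of squalene monooxygenase (Homo sapiens); a higher number here means a weaker inhibitor, a lower number a stronger inhibitor: 450 nM
compound 2 `CCN(C/C=C/C#CC(C)(C)C)Cc1cccc(OCCN(C)S(=O)(=O)c2ccc(F)cc2)c1` in this assay: 255 nM
compound 3 `CCN(C/C=C/C#CC(C)(C)C)Cc1cccc(OCCN(C)S(=O)(=O)c2ccc(Br)cc2)c1` in this assay: 330 nM

Compound 3 stands second highest of the three numbers in this assay, and both neighbours lie within the scatter of it: compound 2 gives 255 nM and compound 1 gives 450 nM, so no order among the three can be read from these values.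

Compound 4 `CCN(C/C=C/C#CC(C)(C)C)Cc1cccc(OCCN(C)S(=O)(=O)c2cccnc2)c1` is not yet measured. Its change from compound 3 is pyridin-3-yl in place of 4-bromophenyl on a sulfonyl sulfur. Within the data shown here, no measured step carries this change. Among the measured compounds shown here, the one measured step, a 1.3-fold higher number from compound 2 to compound 3 (0.11 log units; within the scatter), is within the scatter and concerns a halogen on the same ring, not a ring exchange, so it gives only a weak hint that variation on this sulfonyl aryl ring has so far left the number where it was. Compound 1, which differs from compound 3 in two places, also gives a value within the scatter of compound 3 in this assay. For the measured compounds named here, the step of a 1.1-fold higher number from compound 3 to compound 4 (0.03 log units; within the scatter) is therefore expected to stay within the scatter, in no firm direction, with a wide range because the change has no measured precedent here. Compound 4 is expected to give 350 nM in this assay, within 140 nM to 900 nM.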

Compound 4, half-maximal inhibitory concentration: 150 nM
Beside the measured number, compound 4's estimate is 2.3-fold (0.37 log units) above it, within the range that was stated.
By their numbers in this assay, from the lowest: compounds 4, 2, 3 and 1 (each within the scatter of the next, the first and the last beyond it).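

In this assay this position on the sulfonyl sulfur now shows a step beyond the scatter: pyridin-3-yl in place of 4-bromophenyl gives a 2.2-fold lower number from compound 3 to compound 4 (0.34 log units; beyond the scatter) as a modest change. The same exchange against 4-fluorophenyl gives a 1.7-fold lower number from compound 2 to compound 4 (0.23 log units; within the scatter) and stays within the scatter, so the ring exchange is only clearly resolved against the 4-bromophenyl group. The change of methyl((pyridin-3-yl)sulfonyl)amino for ((thiophen-2-yl)sulfonyl)amino gives a 3.0-fold lower number from compound 1 to compound 4 (0.48 log units; beyond the scatter) and is also modest, though it joins a ring exchange to a methyl on the sulfonamide nitrogen, and no evidence on hand bears on any of these steps.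

On these data alone, how much of that last step belongs to the methyl and how much to the ring stays open. Also open, as far as these compounds go, is what pyridin-4-yl, pyridin-2-yl or plain phenyl would give on the same sulfonyl sulfur.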